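A smaller group returns to the position that lost potency

The compounds below may be only part of what the source reports. "The series", "measured", "known", "first", "only" and "open" are said of these compounds alone.

Compound 1 `CCCc1cc(NC)c2cc(NC(=O)/C=C/c3ccc(C(F)(F)F)cc3)ccc2n1` gives 1.5 nM in an assay on isolated protein for displacement of a labelled ligand from melanin-concentrating hormone receptor 1 (Homo sapiens); on this read-out higher numbers stand for weaker inhibition and lower numbers for stronger inhibition. Compound 3 `CCCc1cc(N)c2cc(NC(=O)c3ccc(-c4ccc(Cl)cc4)cc3)ccc2n1` gives 0.7 nM in this assay. For compound 2 `CCCc1cc(N2CCCCC2)c2cc(NC(=O)/C=C/c3ccc(C(F)(F)F)cc3)ccc2n1` this assay reports only a limit, > 4000 nM. Within the data shown here, compound 2 therefore sits at the limit of > 4000 nM in this assay, at which 1 of the 3 values shown sits, and the only measured change at this position is the step of an at least 2600-fold higher number from compound 1 to compound 2 (3.42 log units; beyond the scatter). Compound 4 `CCCc1cc(OC)c2cc(NC(=O)/C=C/c3ccc(C(F)(F)F)cc3)ccc2n1` differs from compound 2 by methoxy in place of piperidin-1-yl on an aromatic carbon. Because the large step of an at least 2600-fold higher number from compound 1 to compound 2 (3.42 log units; beyond the scatter) followed the entry of piperidin-1-yl, its replacement by the much smaller methoxy is expected to reverse most of that loss. A large downward step an at least 200-fold lower number from compound 2 to compound 4 (2.30 log units; beyond the scatter) is expected in this assay. Compound 4 is estimated at 20 nM, with a range from 3 nM to 150 nM.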

Compound 4, half-maximal inhibitory concentration: 26 nM
Compound 4: the middle estimate sits 1.3-fold (0.11 log units) below what was measured; low and high end bracket the measured number.
By their numbers in this assay, from the lowest: compound 3; then compound 1; then compound 4. At a limit, above all of these: compound 2.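

In this assay, the position opposite the ring nitrogen accepts methoxy far better than piperidin-1-yl, and most of the lost potency returns with an at least 150-fold lower number from compound 2 to compound 4 (2.18 log units; beyond the scatter) as the step. The return is only partial, since a 17-fold higher number from compound 1 to compound 4 (1.24 log units; beyond the scatter) shows that this position also separates methoxy from methylamino. The first of these steps starts from a limit rather than a number: the limit of > 4000 nM in this assay, at which 1 of the 4 values shown sits.

From the compounds shown here alone, whether the ring of piperidin-1-yl or its size drives the loss remains open, and a dimethylamino or morpholine group here would test this. An ethoxy group would show how far a longer chain on oxygen is accepted.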